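Estimating Compound 4 after a Pyridin-3-yl Exchange

This account rests on a few compounds, and the source may have more. Where it says the series, first, only, none or still open, it means among the compounds named here.

In an assay on Sf9 cells for inhibition of protein deacetylase HDAC6 (Homo sapiens), read by fluorescence, with a stated time of 40 min, tested at 100 nM (a lower number here means less inhibition, a higher number more inhibition at the concentration tested (going by the name of the read-out)), compound 3 `COc1ccc(-c2nc(CNc3ccc(C(=O)NO)cc3)n(-c3ccccc3)n2)cc1` gives 77.6%, the highest of the three measured numbers. Compound 2 `Cc1cccc(-c2nc(CNc3ccc(C(=O)NO)cc3)n(-c3ccccc3)n2)c1` gives 64.1% and compound 1 `Cc1ccc(-c2nc(CNc3ccc(C(=O)NO)cc3)n(-c3ccccc3)n2)o1` gives 60.7%; the steps of a number 13.5 percentage points higher from compound 2 to compound 3 (beyond the scatter) and a number 16.9 percentage points higher from compound 1 to compound 3 (beyond the scatter) both lie beyond the scatter, while a number 3.4 percentage points higher from compound 1 to compound 2 (within the scatter) does not. Compound 4 `O=C(NO)c1ccc(NCc2nc(-c3cccnc3)nn2-c2ccccc2)cc1` differs from compound 3 in one place: pyridin-3-yl in place of 4-methoxyphenyl on an aromatic carbon. Going by the values given here, no measured step replaces this group with one whose six-membered ring holds a hetero atom, so the earlier steps bear on it only indirectly; they show that exchanging this group moved the read-out by modest amounts among the measured compounds. A modest loss is therefore expected, a number 12.6 percentage points lower from compound 3 to compound 4 (beyond the scatter). Compound 4 is estimated at 65%, with a range from 45% to 82%.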

Compound 4, a percentage reported as inhibition, at one concentration (the size of the read-out at that concentration, not a potency): 57.7%
Estimate against measurement, compound 4: 7.3 percentage points above; measured number inside the range.
By their numbers in this assay, from the lowest: compounds 4, 1 and 2 (each within the scatter of the next); then compound 3.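

In this assay the first six-membered ring with a hetero atom on this aromatic carbon gives a number 19.9 percentage points lower from compound 3 to compound 4 (beyond the scatter) and so the largest step yet seen at this position. The same exchange gives a number 6.4 percentage points lower from compound 2 to compound 4 (within the scatter) and a number 3 percentage points lower from compound 1 to compound 4 (within the scatter) so that only the 4-methoxyphenyl group of compound 3 stands apart, while pyridin-3-yl, 3-methylphenyl and 5-methylfuran-2-yl cannot be told apart. No evidence available here accounts for these steps. As far as these compounds go, it remains open whether the step from compound 3 follows from the ring nitrogen or the lost methoxy group, and how an aminopyridine or a benzoic acid would read at this position.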